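Methoxy to Nitro on the Aryl Ring

A few compounds are considered here, and "the series" means these few. Any claim that something is new, unique, unknown or untested is made for them only; others in the source may bear on it.

Two measured compounds share one core and differ only on an aromatic carbon of a six-membered aromatic ring of carbon only. Compound 1 `O=C(Cn1c(=O)c(Cc2ccccc2)nc2ccccc21)N/N=C/c1ccccc1` carries hydrogen there, and in an assay for inhibition of Amine oxidase [flavin-containing] B (Bos taurus), read by fluorescence, with a stated time of 60 min (a lower number here means a stronger inhibitor, a higher number a weaker inhibitor), compound 1 gives 880000 nM. Compound 2 `COc1ccc(/C=N/NC(=O)Cn2c(=O)c(Cc3ccccc3)nc3ccccc32)cc1` carries methoxy at that carbon, and in this assay compound 2 gives 82000 nM, the lowest of the two numbers. The step of an 11-fold lower number from compound 1 to compound 2 (1.03 log units; beyond the scatter) is large. Compound 3 `O=C(Cn1c(=O)c(Cc2ccccc2)nc2ccccc21)N/N=C/c1ccc([N+](=O)[O-])cc1` has not been measured; it differs from compound 2 by nitro in place of methoxy on an aromatic carbon. Going by the values given here, no measured step exchanges one group for another at this carbon, and the only step known, an 11-fold lower number from compound 1 to compound 2 (1.03 log units; beyond the scatter), shows that a group placed there can shift the number strongly but gives no direction for nitro against methoxy. The expected step of a 1.5-fold higher number from compound 2 to compound 3 (0.17 log units; within the scatter) is therefore small, with wide uncertainty. Compound 3 is estimated at 120000 nM, with a range from 30000 nM to 500000 nM.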

Compound 3, half-maximal inhibitory concentration: 84000 nM
Compound 3: middle estimate off by 1.4-fold (0.15 log units), on the high side, within the range that was stated.
By their numbers in this assay, from the lowest: compounds 2 and 3 (each within the scatter of the next); then compound 1.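

In this assay, the exchange at this carbon (a 1.0-fold higher number from compound 2 to compound 3 (0.01 log units; within the scatter)) lies within the scatter, so the 4-methoxyphenyl and 4-nitrophenyl compounds cannot be told apart here. Nitro also gives a large step against hydrogen (a 10-fold lower number from compound 1 to compound 3 (1.02 log units; beyond the scatter)), which shows that the drop in the number seen with methoxy is not confined to methoxy: two different groups, each on an aromatic carbon para to a large group, both stand clearly apart from compound 1. Nothing available explains why these two groups give such similar numbers.

Going by these compounds, it remains open whether an amine or a carboxylic acid at this carbon would give a number close to those of compound 2 and compound 3 or one nearer to that of compound 1. Also open, on these data alone, is whether methoxy or nitro would have a similar effect on another carbon of this ring.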